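A few compounds are considered here, and "the series" means these few. Any claim that something is new, unique, unknown or untested is made for them only; others in the source may bear on it.

Series notes:
- compound 1 `CCc1ncnc(NC(C)c2ccc(NC(C)=O)cc2)c1Cl`: > 10000 nM
- compound 2 `CCC(Nc1cc(C)ncn1)c1ccc(Oc2ccc(F)cc2)cc1`: > 10000 nM

In an ADME assay on HEK-293T cells (Homo sapiens) for cytotoxicity, with a stated time of 48 h (a higher number here means that more compound is tolerated, a lower number that less compound is tolerated), compound 2 gives > 10000 nM, which is a limit and not a number. Its standing is therefore known only as a limit, shared with compound 1: the limit of > 10000 nM in this assay, at which 2 of the 2 values shown sit. Compound 3 `CCC(Nc1cc(COC)ncn1)c1ccc(Oc2ccc(F)cc2)cc1` differs from compound 2 by methoxy in place of hydrogen on a saturated chain carbon bound to an aromatic carbon, methyl to methoxymethyl. Among the measured compounds shown here, no measured step in this assay informs this change, so the expectation rests on that shared limit. Expected is a step that the limit leaves unreadable from compound 2 to compound 3, with no change beyond the scatter. The estimate for compound 3 is 12000 nM, with an expected range of 6000 nM to 30000 nM.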

Compound 3, half-maximal cytotoxic concentration: > 10000 nM
Compound 3: no number, only a limit; the forecaster's own chance of this, stated with the estimate: 85%; the middle value lies beyond the limit too.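

No step can be read from compound 2 to compound 3, since each carries only a limit: the limit of > 10000 nM in this assay, at which 3 of the 3 values shown sit.

The compounds shown leave open what number compound 1, compound 2 or compound 3 would reach, and whether methyl to methoxymethyl changes it.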